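Methoxyphenyl in place of pyridinyl: cytotoxicity expectation

The compounds below may be only part of what the source reports. "The series", "measured", "known", "first", "only" and "open" are said of these compounds alone.

Compound 1 `CC(C)c1ccc(C(Nc2ccc(C3(C)NC(=O)c4ccccc4N3)cc2)c2nnnn2C(C)(C)C)cc1`: > 400000 nM; compound 2 `CC1(c2ccc(NC(c3ccc(Cl)cc3)c3nnnn3C(C)(C)C)cc2)NC(=O)c2ccccc2N1`: > 400000 nM; compound 3 `CC1(c2ccc(NC(c3ccncc3)c3nnnn3C(C)(C)C)cc2)NC(=O)c2ccccc2N1`: "not determined" (no result reported).

In an ADME assay on Vero cells (Chlorocebus sabaeus) for cytotoxicity, read by MTT assay, with a stated time of 72 h (on this read-out higher numbers stand for lower toxicity in this test and lower numbers for higher toxicity in this test), compound 1 reaches only a limit of the test, > 400000 nM. Compound 2 likewise gives a limit, > 400000 nM. Compound 3 has no number in this assay, its result being "not determined" (no result reported). The step from compound 1 to compound 2, a step that the two limits leave unreadable from compound 1 to compound 2, is unreadable because of the limit of > 400000 nM in this assay, at which 2 of the 3 values shown sit. Compound 4 `COc1ccc(C(Nc2ccc(C3(C)NC(=O)c4ccccc4N3)cc2)c2nnnn2C(C)(C)C)cc1` differs from compound 3 by 4-methoxyphenyl in place of pyridin-4-yl on a saturated chain carbon bound to an aromatic carbon and a nitrogen on an aromatic ring. Among the compounds with values here, no measured step bears on this change, so nothing beyond the scatter is expected, only the same limit as the others. Compound 4 is expected to give about 400000 nM in this assay, within 200000 nM to 800000 nM.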

Compound 4, half-maximal cytotoxic concentration: > 400000 nM
Compound 4: only a limit was reported; the forecaster's own chance of this, stated with the estimate: 80%; the middle value lies on the limit itself.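

Within the data shown here, no step from compound 1 or compound 2 to compound 4 can be read, because all three give only a limit: the limit of > 400000 nM in this assay, at which 3 of the 4 values shown sit. The compounds shown leave open how their toxicity differs in this assay, and where compound 3 stands.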